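Three Aryl Variants Measured, a Fourth Awaits Its Number

The source may report more compounds than this note shows. Statements on the series, on what has been measured and on what is new or still open speak of the compounds shown alone.

Compound 1 `Cc1oc(-c2c(C)c(C)c(C)c(C)c2C)nc1CN1CCC(C(=O)NCCCN2C[C@H](C)C[C@H](C)C2)CC1`: 8180 nM
Compound 2 `Cc1oc(-c2c(Cl)cccc2Br)nc1CN1CCC(C(=O)NCCCN2C[C@H](C)C[C@H](C)C2)CC1`: 12200 nM
Compound 3 `COc1cccc(Cl)c1-c1nc(CN2CCC(C(=O)NCCCN3C[C@H](C)C[C@H](C)C3)CC2)c(C)o1`: 15800 nM

These three compounds share one core and differ only in the aromatic group attached to it. They were tested in an ADME assay on Huh7.5.1 cells (Homo sapiens) for cytotoxicity, read by ATP content, with a stated time of 48 h (on this read-out lower numbers stand for higher toxicity in this test and higher numbers for lower toxicity in this test), and the values above are those read-outs. Compound 3 has the highest number of the three, but its distances to the others are small: a 1.3-fold higher number from compound 2 to compound 3 (0.11 log units; within the scatter) and a 1.9-fold higher number from compound 1 to compound 3 (0.29 log units; within the scatter), so the three sit together within the scatter.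

Compound 4 `Cc1cc(C)cc(-c2nc(CN3CCC(C(=O)NCCCN4C[C@H](C)C[C@H](C)C4)CC3)c(C)o2)c1` has not yet been measured. The change from compound 3 is 3,5-dimethylphenyl in place of 2-chloro-6-methoxyphenyl on an aromatic carbon. For the measured compounds named here, the steps that bear on it are the two earlier swaps of the whole aromatic group, a 1.5-fold higher number from compound 1 to compound 2 (0.17 log units; within the scatter) and a 1.9-fold higher number from compound 1 to compound 3 (0.29 log units; within the scatter), both within the scatter. Every swap so far has left the number about where it was, so the expectation is a step of no more than the scatter, in no particular direction: a 1.4-fold lower number from compound 3 to compound 4 (0.16 log units; within the scatter). Compound 4 is therefore estimated at 11000 nM, with a range from 4500 nM to 27000 nM.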

Compound 4, half-maximal cytotoxic concentration: 4050 nM
Beside the measured number, compound 4's estimate is 2.7-fold (0.43 log units) above it; measured number below the stated range.
By their numbers in this assay, from the lowest: compound 4; then compounds 1, 2 and 3 (each within the scatter of the next).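

In this assay this position proves not to be indifferent to the aromatic group: a 3.9-fold lower number from compound 3 to compound 4 (0.59 log units; beyond the scatter) and a 3.0-fold lower number from compound 2 to compound 4 (0.48 log units; beyond the scatter) and also a 2.0-fold lower number from compound 1 to compound 4 (0.31 log units; beyond the scatter) all lie beyond the scatter, which gives compound 4 the lowest number of the four and so the highest toxicity in this test. Compound 1 also carries a group built of carbon only, yet compound 4 stands apart from it, so an all-carbon group does not by itself settle the number. No measurement here gives a reason for this change.

On these data alone, it remains open whether the two methyl groups of compound 4 matter in themselves. How a plain phenyl, or a phenyl bearing an amine or a carboxylic acid, would read in this assay also stays unanswered.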